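Fluorine at the outer phenyl ring of two enaminone pairs

The source may hold more compounds than are shown below. What is called first, only, known or untested is meant among the compounds shown, and "the series" means these compounds.

Compound 1 `O=C(/C=C\Nc1ccc(F)cc1)c1cn(-c2ccccc2)nc1-c1ccccc1` and compound 3 `O=C(/C=C\Nc1ccc(F)cc1)c1cn(-c2ccccc2)nc1-c1ccc(F)cc1` share one core; compound 2 `COc1cc(N/C=C\C(=O)c2cn(-c3ccccc3)nc2-c2ccccc2)cc(OC)c1OC` and compound 4 `COc1cc(N/C=C\C(=O)c2cn(-c3ccccc3)nc2-c2ccc(F)cc2)cc(OC)c1OC` share another. The difference between the two cores is not broken down here. In a functional assay on A549 cells (Homo sapiens) for antiproliferative activity, read by MTT assay, with a stated time of 48 h (on this read-out lower numbers stand for stronger inhibition and higher numbers for weaker inhibition), compound 1 gives 4670 nM, and compound 3 gives 5780 nM. The change from compound 1 to compound 3 is fluoro in place of hydrogen on an aromatic carbon, and it produced a 1.2-fold higher number from compound 1 to compound 3 (0.09 log units; within the scatter). Compound 2 gives 6340 nM in this assay, the highest of the three numbers, though the gaps to compound 1 and compound 3 both stay within the scatter. The change from compound 2 to compound 4 is fluoro in place of hydrogen on an aromatic carbon, the same change at the same kind of place, only on the second core. Because the earlier step was a 1.2-fold higher number from compound 1 to compound 3 (0.09 log units; within the scatter), a step of similar size is expected here, a 1.2-fold higher number from compound 2 to compound 4 (0.07 log units; within the scatter). Compound 4 is therefore estimated at 7500 nM, likely between 4000 nM and 14000 nM.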

Compound 4, half-maximal inhibitory concentration: 9350 nM
For compound 4 the middle estimate is 1.2-fold (0.10 log units) below the measured one; low and high end bracket the measured number.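

In this assay, replacing phenyl with 4-fluorophenyl on the core of compound 2 gives a 1.5-fold higher number from compound 2 to compound 4 (0.17 log units; within the scatter), so this step, like the earlier one on the core of compound 1, is no larger than the differences seen between repeated measurements. Set side by side, the two steps cannot be told apart: the same change on two cores in this assay, a 1.2-fold higher number (0.09 log units; within the scatter) from compound 1 to compound 3 and a 1.5-fold higher number (0.17 log units; within the scatter) from compound 2 to compound 4, 1.2-fold (0.08 log units) apart, within the scatter of two such steps This shows that the change behaved alike on these two cores, with no sign that either core alters its outcome, but it does not show that fluoro truly weakens the antiproliferative effect, and two pairs cannot establish a rule for the wider series.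

The compounds shown leave open how a chloro group, an amine or a carboxylic acid would read at this same ring position. They also leave open whether a larger group there would produce a step beyond the scatter, and whether that step would then carry from one core to the other.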